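The compounds below may be only part of what the source reports. "The series", "measured", "known", "first", "only" and "open" are said of these compounds alone.

Measured compounds so far:
Compound 1, `CC1=CC(=O)OC(CSc2nc(-c3ccccc3)c(-c3ccccc3)[nH]2)C1`, gives 200 nM in an assay on microsomes from liver for inhibition of sterol O-acyltransferase 1 (Rattus norvegicus); on this read-out higher numbers stand for weaker inhibition and lower numbers for stronger inhibition.
Compound 2, `CO[C@H]1C[C@H](O)C[C@@H](CSc2nc(-c3ccccc3)c(-c3ccccc3)[nH]2)O1`, gives 90 nM in this assay.
Compound 3, `c1ccc(-c2nc(SCC3CCCCO3)[nH]c2-c2ccccc2)cc1`, gives 210 nM in this assay.

Compound 3 carries the highest of the three numbers, but not by much. One of its steps, a 1.1-fold higher number from compound 1 to compound 3 (0.02 log units; within the scatter), stays within the usual scatter, so these two compounds cannot be told apart on this read-out. The other, a 2.3-fold higher number from compound 2 to compound 3 (0.37 log units; beyond the scatter), lies beyond the scatter, a modest shift.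

Compound 4, `c1ccc(CSc2nc(-c3ccccc3)c(-c3ccccc3)[nH]2)cc1`, is the next compound to be measured. Its difference from compound 3 is this: phenyl in place of oxan-2-yl on a saturated chain carbon bound to a sulfur. All three shared the same core and differed only in the ring attached at that chain carbon, and both measured steps at that place, a 1.1-fold higher number from compound 1 to compound 3 (0.02 log units; within the scatter) and a 2.3-fold higher number from compound 2 to compound 3 (0.37 log units; beyond the scatter), moved the number by little or by a modest amount. Within the data shown here, none of them, however, replaced the saturated ring with an aromatic one, so the present change has no direct precedent among the measured compounds. On that basis a step no larger than those seen is expected, with no firm direction: the estimated step is a 1.2-fold higher number from compound 3 to compound 4 (0.08 log units; within the scatter). For compound 4 the expected value in this assay is 250 nM, with a range from 90 nM to 700 nM.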

Compound 4, half-maximal inhibitory concentration: 290 nM
For compound 4 the middle estimate is 1.2-fold (0.06 log units) below the measured one; the measured number falls inside the stated range.
By their numbers in this assay, from the lowest: compound 2; then compounds 1, 3 and 4 (each within the scatter of the next).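

In this assay, putting an all-carbon aromatic ring where a saturated oxygen-containing ring stood makes no clear difference at this place: a 1.4-fold higher number from compound 3 to compound 4 (0.14 log units; within the scatter) and a 1.5-fold higher number from compound 1 to compound 4 (0.16 log units; within the scatter) both stay within the usual scatter, so compound 4 cannot be told apart from compound 3 or compound 1 on this read-out. Compound 2 remains the only one that stands apart, and a 3.2-fold higher number from compound 2 to compound 4 (0.51 log units; beyond the scatter) is a modest step that lies beyond the scatter, the widest gap among these four compounds. No available measurement bears on what lies behind these numbers.

The ring of compound 2 differs from the oxan-2-yl ring of compound 3 by more than one added group, so these compounds cannot show which of those additions goes with its lower number. They also leave open what would happen with an amine or a carboxylic acid on the ring, or with a longer chain between the sulfur and the ring.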